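This account rests on a few compounds, and the source may have more. Where it says the series, first, only, none or still open, it means among the compounds named here.

Compound 1 `Nc1scc(CN2CCN(c3ccccc3C(F)(F)F)CC2)c1C(=O)c1ccc(Cl)cc1`: 0%
Compound 2 `Nc1scc(CN2CCN(CCCc3ccc(Cl)cc3)CC2)c1C(=O)c1ccc(Cl)cc1`: 0%

In a functional assay on CHO cells with adenosine receptor A1 (Homo sapiens) as the target, read by cAMP accumulation and immunoassay, with a stated time of 6 min, tested at 0.01 uM (on this read-out lower numbers stand for a stronger effect and higher numbers for a weaker effect at the one concentration tested), compound 1 gives 0%, and compound 2 gives 0%. For the measured compounds named here, the one measured step, no change at the digits printed from compound 1 to compound 2 (within the scatter), swapped the group on the ring nitrogen and left the read-out where it was, so compound 2 stands level with compound 1. Compound 3 `Nc1scc(CN2CCN(c3cccc(Cl)c3)CC2)c1C(=O)c1ccc(Cl)cc1` changes the group on that same nitrogen again: 3-chlorophenyl in place of 3-(4-chlorophenyl)propyl on an amine nitrogen in a ring. Going by the values given here, that earlier step is the only guide, and it showed nothing beyond the scatter, so no movement beyond the scatter is expected in this assay, a step of no change at the digits printed from compound 2 to compound 3 (within the scatter). Compound 3 is therefore estimated at 0%, with a range from -10% to 10%.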

Compound 3, a percentage reported as activity, at one concentration (the size of the read-out at that concentration, not a potency): -3.1%
Beside the measured number, compound 3's estimate is 3.1 percentage points above it, within the range that was stated.
By their numbers in this assay, from the lowest: compounds 3, 1 and 2 (each within the scatter of the next).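

In this assay, the read-out shows a number 3.1 percentage points lower from compound 2 to compound 3 (within the scatter) and a number 3.1 percentage points lower from compound 1 to compound 3 (within the scatter) when 3-chlorophenyl goes onto the amine nitrogen in the ring. This position has now carried three different groups, with the chlorophenyl ring either attached directly or held on a propyl chain, and compounds 1, 2 and 3 all remain within the scatter of one another. No supporting measurement bears on why this read-out stays level. As far as these compounds go, whether an amine or a carboxylic acid on that nitrogen would shift the read-out remains open. So does how these compounds behave at any other concentration.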